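Solubility notes on the series, with an estimate for compound 4

This account rests on a few compounds, and the source may have more. Where it says the series, first, only, none or still open, it means among the compounds named here.

Measured so far:
compound 1 `C[C@@H]1[C@@H](N(C)C)CN1c1cc2c(cc1F)c(=O)c(C(=O)O)cn2C1CC1`: 96.3 ug/mL
compound 2 `C[C@@H]1[C@@H](N(C)C)CN1c1c(F)cc2c(=O)c(C(=O)O)cn(C3CC3)c2c1F`: 97.1 ug/mL
compound 3 `CN(C)C1CN(c2c(F)cc3c(=O)c(C(=O)O)cn(C4CC4)c3c2F)C1`: 58 ug/mL

In a physicochemical assay for solubility, at pH 7.4 (on this read-out higher numbers stand for higher solubility and lower numbers for lower solubility), compound 1 stands second highest of the three numbers. Its nearest neighbour is compound 2, with a 1.0-fold higher number from compound 1 to compound 2 (0.00 log units; within the scatter). Its furthest is compound 3, whose 58 ug/mL sits within the scatter of compound 1 all the same.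

Compound 4 `C[C@H]1[C@@H](N)CN1c1cc2c(cc1F)c(=O)c(C(=O)O)cn2C1CC1` differs from compound 1 by a group of 6 heavy atoms (4 carbon, 2 nitrogen; one four-membered non-aromatic ring with 1 hetero atom) in place of a group of 8 heavy atoms (6 carbon, 2 nitrogen; one four-membered non-aromatic ring with 1 hetero atom), on an aromatic carbon. Neither measured step touches this group, and both stayed within the scatter: a 1.0-fold higher number from compound 1 to compound 2 (0.00 log units; within the scatter) and a 1.7-fold lower number from compound 2 to compound 3 (0.22 log units; within the scatter). The second, a hydrogen in place of methyl on the saturated ring, is the closer comparison. No step beyond the scatter is therefore expected, a 1.1-fold higher number from compound 1 to compound 4 (0.04 log units; within the scatter). Compound 4 is estimated at 105 ug/mL, with a range from 50 ug/mL to 220 ug/mL.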

Compound 4, solubility: 6.1 ug/mL
Beside the measured number, compound 4's estimate is 17-fold (1.24 log units) above it, outside the stated range (below it).
By their numbers in this assay, from the lowest: compound 4; then compounds 3, 1 and 2 (each within the scatter of the next).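

In this assay, among these compounds, the change on this aromatic carbon gives a 16-fold lower number from compound 1 to compound 4 (1.20 log units; beyond the scatter) and is the only step beyond the scatter. The group of 6 heavy atoms, with 1 hydrogen-bond donor where the group of 8 heavy atoms has 0, is therefore not interchangeable with it here, unlike the fluoro and ring methyl changes. No measurement shown here accounts for the size of this step.

Going by these compounds, whether a methylamino group on the same four-membered ring would sit with compound 1 or with compound 4 remains open. Also open, on these data alone, is how much of the step follows the amine and how much the ring's stereocentres.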